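Flavone glycoside stereochemistry: predicting an epimer's cytotoxicity

The source may hold more compounds than are shown below. What is called first, only, known or untested is meant among the compounds shown, and "the series" means these compounds.

Measured compounds:
Compound 1 `COc1cc(O)c2c(=O)cc(-c3ccc(O)cc3)oc2c1[C@H]1C[C@H](O)[C@H](O)[C@@H](C)O1`, which in a functional assay on CCRF-CEM cells (Homo sapiens) for cytotoxicity, read by resazurin assay, with a stated time of 48 h (on this read-out lower numbers stand for stronger inhibition and higher numbers for weaker inhibition), gives 2650 nM.
Compound 2 `COc1cc(O)c2c(=O)cc(-c3ccc(O)cc3)oc2c1[C@H]1CC(=O)[C@H](O)[C@@H](C)O1`, which in this assay gives 13300 nM.
Compound 3 `C[C@H]1O[C@@H](c2c(O)cc(O)c3c(=O)cc(-c4ccc(O)cc4)oc23)C[C@H](O)[C@@H]1O`, which in this assay gives 4420 nM.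

Among the three numbers, compound 3 stands second highest: its nearest neighbour is compound 1, with a step of a 1.7-fold higher number from compound 1 to compound 3 (0.22 log units; within the scatter), while compound 2 sits furthest off. The new compound, compound 4 `C[C@H]1O[C@@H](c2c(O)cc(O)c3c(=O)cc(-c4ccc(O)cc4)oc23)C[C@H](O)[C@H]1O`, is related to compound 3 as follows: the two compounds have the same atoms and bonds and differ only in configuration as drawn: 1 of 4 stereo elements differ; a stereocentre at a saturated ring carbon is drawn S in compound 3 and R in compound 4. That is a change of configuration alone, with no group leaving or entering.

Neither measured step addresses configuration directly. The step of a 5.0-fold higher number from compound 1 to compound 2 (0.70 log units; beyond the scatter) involves a replacement of one six-membered ring group by another, and the step of a 1.7-fold higher number from compound 1 to compound 3 (0.22 log units; within the scatter) involves hydrogen in place of methyl on an oxygen. Both concern changes in atoms rather than in the drawn configuration of a saturated ring carbon, so they offer only a loose guide to the magnitude to expect here. Given that, the expected step from compound 3 to compound 4 in this assay is a 1.0-fold lower number from compound 3 to compound 4 (0.00 log units; within the scatter), one that is not expected to exceed the scatter. The estimate for compound 4 is therefore 4400 nM, with a range from 1500 nM to 13000 nM.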

Compound 4, half-maximal inhibitory concentration: 2580 nM
For compound 4 the middle estimate is 1.7-fold (0.23 log units) above the measured one, within the range that was stated.
By their numbers in this assay, from the lowest: compounds 4, 1 and 3 (each within the scatter of the next); then compound 2.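

In this assay, inverting a stereocentre at a saturated ring carbon, drawn S in compound 3 and R in compound 4, gives a 1.7-fold lower number from compound 3 to compound 4 (0.23 log units; within the scatter), so this assay does not separate the two drawn configurations for this pair. Going by these compounds alone, until now, the only step that altered the saturated ring was a 5.0-fold higher number from compound 1 to compound 2 (0.70 log units; beyond the scatter), where the ring group with a carbonyl in compound 2 stands beyond the scatter of the ring group in compound 1, whereas this new step shows that a change at a ring carbon need not leave the scatter, at least for this one stereocentre without the methyl on oxygen. The reading can be tied to configuration alone, with no other structural change to account for it, because of one fact: the fact that compounds 3 and 4 differ only in the configuration as drawn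

The compounds shown leave open whether inverting any of the other stereo elements, or this same stereocentre in the series that carries the methyl on oxygen, would also stay within the scatter. They also leave open how an amine or a fluorine in place of the hydroxyl on this ring carbon would read in this assay.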